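This account rests on a few compounds, and the source may have more. Where it says the series, first, only, none or still open, it means among the compounds named here.

Compound 1 `COc1cccc(N2C(=O)COc3ccc(-c4cccc(NS(=O)(=O)c5ccc(F)cc5)c4)cc32)c1`: > 40000 nM
Compound 2 `COc1ccc(N2C(=O)COc3ccc(-c4cccc(NS(=O)(=O)c5ccc(F)cc5)c4)cc32)cc1`: 32400 nM

Among the measured compounds shown here, in a functional assay on MCF7 cells (Homo sapiens) for antiproliferative activity, read by MTT assay, with a stated time of 72 h (on this read-out lower numbers stand for stronger inhibition and higher numbers for weaker inhibition), compound 2 gives 32400 nM, the only actual number so far. The entry for compound 1, > 40000 nM, is a limit of the assay and not a number.

Compound 3 `O=C1COc2ccc(-c3cccc(NS(=O)(=O)c4ccc(F)cc4)c3)cc2N1C1CCCCC1` is the next comparison with compound 2. The change is cyclohexyl in place of 4-methoxyphenyl on an amide-type nitrogen in a ring.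

For the measured compounds named here, only one measured step bears on this site: an at least 1.2-fold lower number from compound 1 to compound 2 (0.09 log units; that floor lies within the scatter). That step swaps one methoxyphenyl group for another, so it shows no large effect from that swap but gives no direct measure of replacing an aromatic ring with a non-aromatic one. The data therefore support no expected direction of change and no expected shift beyond the scatter in this assay.

The expected step is a 1.1-fold lower number from compound 2 to compound 3 (0.03 log units; within the scatter). A limit rather than a number remains a real possibility for compound 3.

The estimate for compound 3 is 30000 nM, with an expected range of 10000 nM to 60000 nM.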

Compound 3, half-maximal inhibitory concentration: 21400 nM
The estimate for compound 3 lay 1.4-fold (0.15 log units) above the measured number; low and high end bracket the measured number.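

In this assay, among the compounds shown here, cyclohexyl in place of 4-methoxyphenyl on the amide-type nitrogen gives the first direct reading of a non-aromatic ring at this position: a 1.5-fold lower number from compound 2 to compound 3 (0.18 log units; within the scatter). A measurable value in this assay therefore does not depend on an aromatic ring or a methoxy oxygen on this nitrogen, at least for these two compounds, and the swap gives no resolved gain or loss. Cyclohexyl in place of 3-methoxyphenyl gives an at least 1.8-fold lower number from compound 1 to compound 3 (0.27 log units; that floor lies within the scatter), and the entry for compound 1 is a limit of the assay and not a number, so this step is only a floor and cannot show how far the two compounds truly lie apart: the limit of > 40000 nM in this assay, at which 1 of the 3 values shown sits.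

The compounds shown leave open whether anything at this nitrogen can move the number beyond the scatter, for instance a plain methyl, a chain ending in an amine, or a carboxylic acid. All three compounds also differ only at this nitrogen, so the contribution of the 4-fluorophenyl sulfonamide and of the rest of the shared core remains unread.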